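A few compounds are considered here, and "the series" means these few. Any claim that something is new, unique, unknown or untested is made for them only; others in the source may bear on it.

Values in a physicochemical assay for solubility, measured as kinetic solubility, with a stated time of 1 h, at pH 7.4; on this read-out higher numbers stand for higher solubility and lower numbers for lower solubility:
- compound 1 `CC(=O)Nc1nc(-c2cccc(O)c2)cs1`: 103000 nM
- compound 2 `N#CCC(=O)Nc1csc(-c2ccc(Cl)c(Cl)c2)c1`: 10000 nM
- compound 3 `CC(=O)NC1=NN(c2ccc(Cl)c(Cl)c2)CC1`: 31000 nM

Compound 3 holds the middle place of the three numbers, under compound 1 and over compound 2, with both gaps beyond the scatter. Compound 4 `N#CCCC(=O)NC1=NN(c2ccc(Cl)c(Cl)c2)CC1` is the next to be read. It differs from compound 3 by one change: cyanomethyl in place of hydrogen on a saturated chain carbon bound to a carbonyl carbon.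

Within the data shown here, no pair of measured compounds differs in one place, so the series gives no direct guide to the size of this step. Among the measured compounds shown here, the only hint is compound 2, whose amide chain also ends in a nitrile, at 10000 nM, though its core is not that of compound 3. A small fall is expected, likely within the scatter, and the estimated change is a 1.6-fold lower number from compound 3 to compound 4 (0.19 log units; within the scatter). For compound 4 the estimated value is 20000 nM, with an expected range of 7000 nM to 50000 nM.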

Compound 4, solubility: 39000 nM
Beside the measured number, compound 4's estimate is 2.0-fold (0.29 log units) below it; measured number inside the range.
By their numbers in this assay, from the lowest: compound 2; then compounds 3 and 4 (each within the scatter of the next); then compound 1.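

Among these compounds, this is the first one-place step: in this assay cyanomethyl in place of hydrogen on a saturated chain carbon bound to a carbonyl carbon gives a 1.3-fold higher number from compound 3 to compound 4 (0.10 log units; within the scatter) on the shared core. At this position, the acetyl and (2-cyanoethyl)carbonyl amides therefore cannot be told apart on this read-out, since the step lies within the scatter. No measurement at hand accounts for this result.

A single step on a single core does not show whether the same change would read alike on the core of compound 1 or the core of compound 2. Also open, on these data alone, is how an amine, a carboxylic acid or a longer chain ending in a nitrile would read at this same position.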